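The source may report more compounds than this note shows. Statements on the series, on what has been measured and on what is new or still open speak of the compounds shown alone.

Within the data shown here, compound 1 `Clc1cccc(CSc2nnc(-c3ccncc3)n2-c2ccccc2)c1` gives 11200 nM in a functional assay on HepG2 cells (Homo sapiens) for inhibition, read by MTT assay, with a stated time of 48 h (on this read-out higher numbers stand for weaker inhibition and lower numbers for stronger inhibition), the lowest of the two numbers so far; its nearest neighbour is compound 2 `Brc1ccc(CSc2nnc(-c3ccncc3)n2-c2ccccc2)cc1`, which gives 12900 nM, and the step of a 1.2-fold higher number from compound 1 to compound 2 (0.06 log units; within the scatter) lies within the scatter. Compound 3 `O=[N+]([O-])c1ccccc1CSc1nnc(-c2ccncc2)n1-c1ccccc1` carries the change (2-nitrophenyl in place of 3-chlorophenyl on a saturated chain carbon bound to a sulfur). Among the measured compounds shown here, the only measured step alters the same aryl group and moved nothing beyond the scatter; no nitro analogue has been measured. Compound 3 is therefore expected to show no step beyond the scatter, a 1.2-fold higher number from compound 1 to compound 3 (0.06 log units; within the scatter), with an estimated 13000 nM and a range from 5000 nM to 35000 nM.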

Compound 3, half-maximal inhibitory concentration: > 50000 nM
Compound 3: only a limit was reported; the forecaster's own chance of this, stated with the estimate: 10%; at least 3.8-fold (0.58 log units) between middle value and limit.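

In this assay, the aryl group on a saturated chain carbon bound to a sulfur proves sensitive to change: 2-nitrophenyl gives an at least 4.4-fold higher number from compound 1 to compound 3 (0.64 log units; beyond the scatter) and an at least 3.8-fold higher number from compound 2 to compound 3 (0.58 log units; beyond the scatter), whereas the earlier step, a 1.2-fold higher number from compound 1 to compound 2 (0.06 log units; within the scatter), stayed within the scatter. As far as these compounds go, the value of compound 3 is a limit and not a number, and the full size of both steps stays unknown: the limit of > 50000 nM in this assay, at which 1 of the 3 values shown sits. From the compounds shown here alone, whether the steps follow the nitro group itself or its place on the phenyl ring stays open, as does the reading for a phenyl carrying an amine or a carboxylic acid at this position.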